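Amino to hydrogen on the ring nitrogen of compound 3

This account rests on a few compounds, and the source may have more. Where it says the series, first, only, none or still open, it means among the compounds named here.

All three measured compounds share one core, and in an assay on CHO cells for displacement of a labelled ligand from adenosine receptor A3 (Homo sapiens), read by scintillation counting, with a stated time of 120 min, tested at 1 uM (a lower number here means less inhibition, a higher number more inhibition at the concentration tested (going by the name of the read-out)), their numbers of inhibition lie level with one another. Compound 1 `CC(C)n1nc(-c2ccccn2)c2sccc2c1=O` gives 2%, compound 2 `Nn1nc(-c2cccs2)c2sccc2c1=O` gives 1% and compound 3 `Nn1nc(-c2nccs2)c2sccc2c1=O` gives 5%. On these numbers compound 3 holds the highest value, but the gaps to compound 1 and to compound 2 both lie within the scatter, so no ordering among the three can be read from this assay. Among the compounds with values here, the only single-point step measured, a number 4 percentage points higher from compound 2 to compound 3 (within the scatter), also lies within the scatter.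

Compound 4 `O=c1[nH]nc(-c2nccs2)c2sccc12` differs from compound 3 by hydrogen in place of amino on an aromatic nitrogen. Within the data shown here, no measured step touches this nitrogen: compound 1 carries an isopropyl there and compound 2 an amino, but those two differ from each other in a second place as well, and their values of inhibition are in any case inseparable within the scatter. With every measured value and step of this series sitting near the floor of the read-out, the expected step of a number 1 percentage points lower from compound 3 to compound 4 (within the scatter) is none beyond the scatter. Compound 4 is therefore estimated at 4% in this assay, with a range from -5% to 15%.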

Compound 4, a percentage reported as inhibition, at one concentration (the size of the read-out at that concentration, not a potency): 1%
For compound 4 the middle estimate is 3 percentage points above the measured one, within the range that was stated.
By their numbers in this assay, from the lowest: compounds 2, 4, 1 and 3 (each within the scatter of the next).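

In this assay, within the data shown here, a number 4 percentage points lower from compound 3 to compound 4 (within the scatter) is the first reading at this ring nitrogen with the 1,3-thiazol-2-yl group held fixed, so the swap of amino for hydrogen is isolated here from any change elsewhere on the shared core. Amino and hydrogen cannot be told apart at this position: losing the amino, with its one hydrogen-bond donor and one acceptor, leaves the read-out level, and both compounds stay at the low end of the numbers seen in this series. No supporting data bear on this result.

On these data alone, whether a methyl group, a longer alkyl chain, or a chain ending in an amine or a carboxylic acid on this nitrogen would lift the number clear of the scatter stays open. So does whether this position has any influence on the read-out at all, given that the pair shown here gives no separable difference.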